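The source may hold more compounds than are shown below. What is called first, only, known or untested is meant among the compounds shown, and "the series" means these compounds.

Measured in a functional assay on cells (Leukemia cell, Homo sapiens) for inhibition; on this read-out lower numbers stand for stronger inhibition of growth and higher numbers for weaker inhibition of growth:
- compound 1 `Cc1cn2c(/C=N/Nc3ccccn3)c(-c3ccc(Cl)c([N+](=O)[O-])c3)nc2s1`: 33900 nM
- compound 2 `Cc1cn2c(/C=N/NC(=N)N)c(-c3ccsc3)nc2s1`: 46800 nM
- compound 3 `N=C(N)N/N=C/c1c(-c2cc(Cl)sc2Cl)nc2n1CCS2`: 24500 nM

Compound 2 stands within the usual scatter of both compound 1 and compound 3, so the three values give no order. Compound 4 `N=C(N)N/N=C/c1c(-c2ccsc2)nc2sccn12` differs from compound 2 in one place: hydrogen in place of methyl on an aromatic carbon. Going by the values given here, no measured pair isolates this change. Compound 3 differs from compound 2 in more than this methyl and carries none on its core. Compound 3 gives 24500 nM, which lies within the scatter of compound 2. No change beyond the scatter is therefore expected in this assay. The expected step is a 1.2-fold lower number from compound 2 to compound 4 (0.07 log units; within the scatter). For compound 4 the estimated value is 40000 nM, with an expected range of 20000 nM to 80000 nM.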

Compound 4, concentration for total growth inhibition: 24000 nM
Compound 4: middle estimate off by 1.7-fold (0.22 log units), on the high side; the range from low to high includes it.
By their numbers in this assay, from the lowest: compounds 4, 3, 1 and 2 (each within the scatter of the next).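

In this assay, hydrogen in place of methyl on the aromatic carbon next to the ring sulfur now stands alone in one pair, which reads a 2.0-fold lower number from compound 2 to compound 4 (0.29 log units; within the scatter) for this single change. At this position, the methyl and hydrogen compounds are therefore not separated by this read-out. No measurement on hand explains this result.

From the compounds shown here alone, whether an ethyl group, a chlorine atom, an amine or a carboxylic acid at this carbon would give a value beyond the scatter stays open. Also open, going by these compounds, is whether the same swap on compound 1 would read alike.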